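The compounds below may be only part of what the source reports. "The series", "measured", "known", "first", "only" and "open" are said of these compounds alone.

Of the compounds shown here, three have been measured so far in an ADME assay on 184B5 cells (Homo sapiens) for cytotoxicity, read by MTT assay, with a stated time of 72 h; on this read-out lower numbers stand for stronger inhibition of growth and higher numbers for weaker inhibition of growth. Compound 1 `CSc1ccc(CNc2nc(SC)nc3ncccc23)cc1` gives 190 nM, compound 2 `CCCCC[Se]c1nc(N)c2ccccc2n1` gives 15300 nM, and compound 3 `COc1ccc(CNc2nc([SeH])nc3ccccc23)cc1` gives 71300 nM. Among these three numbers, compound 2 stands second highest: its nearest neighbour is compound 3, and compound 1 lies much further away with a far lower number. Compound 4 `C[Se]c1nc(N)c2ccccc2n1` has not yet been measured. It differs from compound 2 in one place: hydrogen in place of butyl on a saturated chain carbon bound to a selenium atom. For the measured compounds named here, no measured pair of compounds shows this change, so the expected step rests on judgment alone; in this assay a modest rise in the number, only a little beyond the usual scatter, seems most likely, though a step in either direction is plausible. For compound 4 the value is therefore estimated at 30000 nM, with a likely range from 8000 nM to 120000 nM. That estimate means an expected step of a 2.0-fold higher number from compound 2 to compound 4 (0.29 log units; within the scatter).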

Compound 4, concentration for 50% growth inhibition: 24400 nM
Compound 4: middle estimate off by 1.2-fold (0.09 log units), on the high side; low and high end bracket the measured number.
By their numbers in this assay, from the lowest: compound 1; then compounds 2 and 4 (each within the scatter of the next); then compound 3.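

In this assay, hydrogen in place of butyl on a saturated chain carbon bound to a selenium atom gives a 1.6-fold higher number from compound 2 to compound 4 (0.20 log units; within the scatter). This first pair for the change shows that going from pentyl to methyl at this position leaves the number within the usual scatter. No measurement shown explains this result. The two ends of the range are covered, but a propyl chain, a longer chain such as octyl, or an amine in this place could still give a different number.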